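Replacing the piperidine tail on the phenoxy chain

This account rests on a few compounds, and the source may have more. Where it says the series, first, only, none or still open, it means among the compounds named here.

Measured so far:
compound 1 `Cn1c(=O)c2[nH]c(-c3ccc(OCCC4CCNCC4)cc3)nc2n(C)c1=O`: in an assay on CHO cells for displacement of a labelled ligand from adenosine receptor A3 (Homo sapiens), read by scintillation counting, with a stated time of 3 h (on this read-out higher numbers stand for weaker inhibition and lower numbers for stronger inhibition), compound 1 gives 6.51 nM.
compound 2 `Cn1c(=O)c2[nH]c(Cc3ccc(OCCCCl)cc3)nc2n(C)c1=O`: in this assay compound 2 reaches only the limit > 30 nM, which is not a number (the limit of > 30 nM in this assay, at which 1 of the 2 values shown sits).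

Among the measured compounds shown here, compound 1 therefore holds the only numerical value in this set. For the measured compounds named here, no single-point step between measured compounds is available. Compound 3 `Cn1c(=O)c2[nH]c(-c3ccc(OCCCn4ccnc4)cc3)nc2n(C)c1=O` carries (1H-imidazol-1-yl)methyl in place of piperidin-4-yl on a saturated chain carbon, two bonds along the chain from an oxygen on an aromatic ring. A modest weakening is expected, a 2.3-fold higher number from compound 1 to compound 3 (0.36 log units; beyond the scatter), a change near the edge of the scatter. Compound 3 is accordingly estimated at 15 nM, with a range from 4 nM to 60 nM.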

Compound 3, inhibition constant: 2.27 nM
Estimate against measurement, compound 3: 6.6-fold (0.82 log units) above, outside the stated range (below it).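

At this chain end, (1H-imidazol-1-yl)methyl in place of piperidin-4-yl gives, in this assay, a 2.9-fold lower number from compound 1 to compound 3 (0.46 log units; beyond the scatter). The position therefore accepts a five-membered aromatic ring with 0 hydrogen-bond donors in place of a six-membered non-aromatic ring with 1 hydrogen-bond donor, without loss on this read-out. Nothing measured here accounts for the step.

As far as these compounds go, whether the step follows the ring itself or its attachment through the extra chain carbon remains open. A morpholin-4-yl group, a dimethylamino group or a 2-(1H-imidazol-1-yl)ethyl chain at this position would bear on that.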